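Carbonyl substituent series: ring contraction to compound 3

The source may hold more compounds than are shown below. What is called first, only, known or untested is meant among the compounds shown, and "the series" means these compounds.

Compound 1 `CC(C)(C)OC(=O)N1CCC(O[C@H]2CC[C@H](Oc3cnc(S(C)(=O)=O)cn3)CC2)CC1` and compound 2 `CS(=O)(=O)c1cnc(O[C@H]2CC[C@H](OC3CCN(C(=O)C4(C(F)(F)F)CCCC4)CC3)CC2)cn1` share a core and differ only in the group on the carbonyl carbon bound to the ring nitrogen. In a functional assay on isolated protein for agonist activity at Glucose-dependent insulinotropic receptor (Rattus norvegicus), read by HTRF and cAMP accumulation (a higher number here means that more compound is needed for the effect, a lower number that less compound is needed), compound 1 gives 64 nM and compound 2 gives 108 nM. For the measured compounds named here, the step of a 1.7-fold higher number from compound 1 to compound 2 (0.23 log units; within the scatter) is the only measured step, and it does not separate the two compounds: compound 2 and compound 1 sit within the scatter of each other, so neither number stands apart on the data so far.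

Compound 3 `CS(=O)(=O)c1cnc(O[C@H]2CC[C@H](OC3CCN(C(=O)C4(C(F)(F)F)CC4)CC3)CC2)cn1` is the next member, with the change (a group of 7 heavy atoms (4 carbon, 3 fluorine; one three-membered non-aromatic ring of carbon only) in place of a group of 9 heavy atoms (6 carbon, 3 fluorine; one five-membered non-aromatic ring of carbon only), on a carbonyl carbon). Going by the values given here, the one measured step that bears on this position, a 1.7-fold higher number from compound 1 to compound 2 (0.23 log units; within the scatter), exchanged a larger, more different substituent on the same carbonyl carbon and still stayed within the scatter. Nothing measured here points to a direction for a smaller ring carrying the same trifluoromethyl. The expected step in this assay from compound 2 is a 1.1-fold lower number from compound 2 to compound 3 (0.03 log units; within the scatter), with no movement beyond the scatter anticipated. Compound 3 is estimated at 100 nM, with a range of 45 nM to 220 nM.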

Compound 3, half-maximal effective concentration: 1380 nM
The estimate for compound 3 lay 14-fold (1.14 log units) below the measured number, and the stated range ends below it.
By their numbers in this assay, from the lowest: compounds 1 and 2 (each within the scatter of the next); then compound 3.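

In this assay, the group on this carbonyl carbon is not interchangeable, even with the trifluoromethyl kept: going from the five-membered ring to 1-(trifluoromethyl)cyclopropyl gives a 13-fold higher number from compound 2 to compound 3 (1.11 log units; beyond the scatter), whereas the earlier exchange at this place gave only a 1.7-fold higher number from compound 1 to compound 2 (0.23 log units; within the scatter). The comparison with tert-butoxy points the same way, at a 22-fold higher number from compound 1 to compound 3 (1.33 log units; beyond the scatter), so among the three groups shown, 1-(trifluoromethyl)cyclopropyl alone stands apart, and the tolerance suggested by the first two compounds does not extend to every group at this place. No supporting data accompany the result to explain the loss, so the step stands as an observation only.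

With only two ring sizes carrying the trifluoromethyl, the compounds shown leave open whether 1-(trifluoromethyl)cyclobutyl would stay with the five-membered ring or with the cyclopropyl, and whether 1-(trifluoromethyl)cyclohexyl would keep the lower number. They also leave open whether the cyclopropyl ring itself or its combination with the trifluoromethyl carries the step, a question that 1-methylcyclopropyl on the same carbonyl carbon would address.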